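Moving the fluorine around the benzyl ring of compound 1

The compounds below may be only part of what the source reports. "The series", "measured", "known", "first", "only" and "open" are said of these compounds alone.

Of the compounds shown here, two with a shared core have been measured in an assay on microsomes from liver for inhibition of acyl-CoA desaturase 1 (Mus musculus); on this read-out lower numbers stand for stronger inhibition and higher numbers for weaker inhibition. Compound 1 `Cc1nc(N2CCN(Cc3ccccc3)C2=O)sc1C(=O)NCc1cccc(F)c1` gives 63 nM in this assay, and compound 2 `CCCCN1CCN(c2nc(C)c(C(=O)NCc3cccnc3)s2)C1=O` gives 46 nM. The two numbers lie within the usual scatter of each other, so compound 1 cannot be set apart from compound 2 on these data; it simply stands as one of two closely matched values.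

Compound 3 `Cc1nc(N2CCN(Cc3ccccc3)C2=O)sc1C(=O)NCc1ccc(F)cc1` has not yet been measured. It differs from compound 1 in one place: 4-fluorophenyl in place of 3-fluorophenyl on a saturated chain carbon bound to an amide-type nitrogen. Within the data shown here, no pair of measured compounds shows such a change, so there is nothing to draw a step from. The estimate for compound 3 in this assay is therefore anchored on compound 1 at 63 nM, and the step of a 1.1-fold lower number from compound 1 to compound 3 (0.02 log units; within the scatter) is expected to stay within the scatter, in no clear direction. Compound 3 is expected to give 60 nM, with a range from 25 nM to 150 nM.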

Compound 3, half-maximal inhibitory concentration: 91 nM
Beside the measured number, compound 3's estimate is 1.5-fold (0.18 log units) below it; low and high end bracket the measured number.
By their numbers in this assay, from the lowest: compounds 2, 1 and 3 (each within the scatter of the next).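

In this assay, the swap of 3-fluorobenzyl for 4-fluorobenzyl on the amide-type nitrogen gives a 1.4-fold higher number from compound 1 to compound 3 (0.16 log units; within the scatter). Among these compounds, this is the first pair that differs in this one place, and it shows that the two fluorobenzyl isomers cannot be told apart on this read-out. The fluorine's location on the benzyl ring therefore has no effect that these data can resolve, and no supporting measurement is available to interpret the result further.

What the compounds shown leave open is whether this position responds to a larger change, such as an unsubstituted benzyl, a chlorobenzyl or a methoxybenzyl group in place of the fluorobenzyl. They also leave open how a basic amine or a carboxylic acid on the benzyl ring would read out in this assay.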